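Swapping a Hydroxyl Tail for Phenyl on a Pyrimidine Core

The compounds below may be only part of what the source reports. "The series", "measured", "known", "first", "only" and "open" are said of these compounds alone.

Compound 1 `CCCCNc1nc(N)nc(C)c1CCCCO`: 1310 nM
Compound 2 `CCCCNc1nc(N)nc(C)c1CCCN1C(=O)c2ccccc2C1=O`: 453 nM
Compound 3 `CCCCNc1nc(N)nc(C)c1C#CCN1CCCCC1`: 3790 nM

Three compounds sharing one core were tested in an assay on HEK293 cells for agonist activity at Toll-like receptor 8 (Homo sapiens), read by spectrophotometry; on this read-out higher numbers stand for an effect only at larger amounts of compound and lower numbers for an effect already at smaller amounts. Compound 1 holds the second highest of the three numbers: compound 2 sits lower and compound 3 sits higher, each gap lying beyond the usual scatter. Compound 4 `CCCCNc1nc(N)nc(C)c1CCc1ccccc1` has not yet been measured. It differs from compound 1 by phenyl in place of 2-hydroxyethyl on a saturated chain carbon, two bonds along the chain from an aromatic carbon, so the hydroxyl-bearing tail becomes a flat aromatic one. Compound 2, which also carries an aromatic end on its chain, shows the lowest number here, and compound 3 with its saturated ring the highest. On that basis, compound 4 is expected to move in the direction of compound 2, a step of a 2.2-fold lower number from compound 1 to compound 4 (0.34 log units; beyond the scatter). Compound 4 is estimated at 600 nM, within 200 nM to 2000 nM.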

Compound 4, half-maximal effective concentration: 1190 nM
For compound 4 the middle estimate is 2.0-fold (0.30 log units) below the measured one, and the stated range covers the measured number.
By their numbers in this assay, from the lowest: compound 2; then compounds 4 and 1 (each within the scatter of the next); then compound 3.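

In this assay, putting phenyl in place of 2-hydroxyethyl on a saturated chain carbon, two bonds along the chain from an aromatic carbon, gives a 1.1-fold lower number from compound 1 to compound 4 (0.04 log units; within the scatter). Among the compounds shown here, this is the first direct comparison at this position, and it shows that the hydroxyl-bearing tail and the aromatic tail cannot be told apart here. Removing the hydrogen-bond donor and acceptor while adding the ring leaves no measurable difference. On these data alone, whether an amine or a carboxylic acid at this chain end would also match remains open. Nothing available here explains the match.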